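Iodo to Thiophen-3-yl on a Methoxy Nucleoside Core

The compounds below may be only part of what the source reports. "The series", "measured", "known", "first", "only" and "open" are said of these compounds alone.

Of the compounds shown here, three have so far been tested in a functional assay on K562 cells (Homo sapiens), read by MTT assay, with a stated time of 72 h; a lower number here means a stronger inhibitor, a higher number a weaker inhibitor. Among the measured compounds shown here, compound 2 `COc1ncnc2c1c(I)cn2[C@@H]1O[C@H](CO)[C@@H](O)[C@H]1O` is the only one to yield a number: in this assay compound 2 gives 14800 nM. Compound 1 `Nc1nc(N)c2c(-c3ccsc3)cn([C@@H]3O[C@H](CO)[C@@H](O)[C@H]3O)c2n1` reaches only a limit of the assay, > 20000 nM. Compound 3 `O=c1[nH]cnc2c1c(-c1cc3ccccc3o1)cn2[C@@H]1O[C@H](CO)[C@@H](O)[C@H]1O` likewise stops at a limit, > 20000 nM. Compound 2 therefore stands alone with a measured value, the other two results being limits, as the limit of > 20000 nM in this assay, at which 2 of the 3 values shown sit, records.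

Compound 4 `COc1ncnc2c1c(-c1ccsc1)cn2[C@@H]1O[C@H](CO)[C@@H](O)[C@H]1O` is not yet measured. It differs from compound 2 in one place: thiophen-3-yl in place of iodo on an aromatic carbon. Compound 1 carries the same thiophen-3-yl group on a different core and in this assay gives only a limit, > 20000 nM, so no large gain is expected from the change. The expected step is a 1.1-fold higher number from compound 2 to compound 4 (0.03 log units; within the scatter), toward weaker inhibition or none beyond the scatter. Compound 4 is accordingly estimated at 16000 nM, with a range from 5000 nM to 40000 nM.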

Compound 4, half-maximal inhibitory concentration: 3450 nM
Compound 4: middle estimate off by 4.6-fold (0.67 log units), on the high side; measured number outside the range, below it.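

In this assay, the aromatic carbon two ring bonds from the ring nitrogen proves sensitive to what it carries: thiophen-3-yl in place of iodo gives a 4.3-fold lower number from compound 2 to compound 4 (0.63 log units; beyond the scatter). This is the only measured step shown, and it shows that on the shared core this carbon accepts an aromatic ring and that the change goes with stronger inhibition, not weaker. The step rests on a single pair, and the other results offer no second step to set beside it: the limit of > 20000 nM in this assay, at which 2 of the 4 values shown sit.

The compounds shown leave open whether the change in inhibition is specific to thiophen-3-yl or would also appear with a phenyl ring or an amine on this carbon. They also leave open whether it would carry over to a core with another group in place of the methoxy group.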